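The source may report more compounds than this note shows. Statements on the series, on what has been measured and on what is new or still open speak of the compounds shown alone.

Of the compounds shown here, three built on one shared core have been measured in an in vitro functional assay on HEK285-7 cells for antagonist activity at prostaglandin D2 receptor 2 (Homo sapiens), read by BRET and beta-arrestin recruitment; a lower number here means a smaller maximal response, a higher number a larger maximal response. Compound 1 `O=C(O)Cc1sc(C(c2ccc(F)cc2)c2ccc(F)cc2)nc1-c1ccnc(Cl)c1` gives 80% in this assay, compound 2 `NS(=O)(=O)c1cccc(-c2nc(C(c3ccc(F)cc3)c3ccc(F)cc3)sc2CC(=O)O)c1` gives 55%, and compound 3 `O=C(O)Cc1sc(C(c2ccc(F)cc2)c2ccc(F)cc2)nc1-c1ccccc1` gives 80%. Compound 3 thus stands level with compound 1, the two together forming the highest pair of the three numbers; the step of no change at the digits printed from compound 1 to compound 3 (within the scatter) stays within the scatter, whereas a number 25 percentage points lower from compound 1 to compound 2 (beyond the scatter) and a number 25 percentage points higher from compound 2 to compound 3 (beyond the scatter) go beyond it. The unmeasured compound 4 `O=C(O)Cc1sc(C(c2ccc(F)cc2)c2ccc(F)cc2)nc1-c1ccncc1` differs from compound 3 in a single place: pyridin-4-yl in place of phenyl on an aromatic carbon. The measured step that bears most directly on this change is no change at the digits printed from compound 1 to compound 3 (within the scatter), in which a 2-chloropyridin-4-yl group and a phenyl gave the same reading; the two steps involving compound 2 concern the sulfamoyl group and speak less directly to it. Because the 2-chloropyridin-4-yl group of compound 1 gave 80%, the pyridin-4-yl of compound 4 is expected to produce a step of a number 2 percentage points lower from compound 3 to compound 4 (within the scatter), that is, none beyond the scatter. Compound 4 is therefore estimated at 78%, with a range from 65% to 90%.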

Compound 4, largest response reached (reported as efficacy), in percent of the reference or control that the assay uses: 80%
Estimate against measurement, compound 4: 2 percentage points below; the measured number falls inside the stated range.
By their numbers in this assay, from the lowest: compound 2; then compounds 1, 3 and 4 (each within the scatter of the next).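

In this assay, pyridin-4-yl in place of phenyl gives no change at the digits printed from compound 3 to compound 4 (within the scatter), so the hydrogen-bond acceptor that enters with pyridin-4-yl leaves the maximal response unchanged at this position, and hydrogen in place of chloro gives no change at the digits printed from compound 1 to compound 4 (within the scatter), showing that the chloro of compound 1 was not needed to match the reading of compound 3. For the compounds shown here, with a number 25 percentage points higher from compound 2 to compound 4 (beyond the scatter) as well, the 3-sulfamoylphenyl of compound 2 is the only group among the four that separates from the others. Nothing available explains why these groups read alike or why compound 2 reads apart.

Going by these compounds, it remains open whether an amine or a methoxy group in the place of the chloro would keep this reading. On these data alone, it is equally open whether a carboxamide in the place of the sulfamoyl group would give the reading of compound 2 or that of compound 3.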